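Methoxycarbonyl in Place of 2-Methoxyphenyl: Expected Loss

A few compounds are considered here, and "the series" means these few. Any claim that something is new, unique, unknown or untested is made for them only; others in the source may bear on it.

For the measured compounds named here, compound 2 `COc1ccccc1-c1ccc(S(=O)(=O)N2CCC(N3CCC(C)CC3)CC2)cc1` holds the only number in the set: in a functional assay on DLD-1 cells (Homo sapiens) for antiproliferative activity, read by CellTiter-Glo, with a stated time of 72 h (on this read-out lower numbers stand for stronger inhibition and higher numbers for weaker inhibition), compound 2 gives 26 nM. Compound 1 `CC1CCN(C2CCN(S(=O)(=O)c3cccc(C(F)(F)F)c3)CC2)CC1` reaches only a limit, > 5000 nM, in this assay. The remaining shown value thus sits at the limit of > 5000 nM in this assay, at which 1 of the 2 values shown sits. Compound 3 `COC(=O)c1ccc(S(=O)(=O)N2CCC(N3CCC(C)CC3)CC2)cc1` differs from compound 2 by methoxycarbonyl in place of 2-methoxyphenyl on an aromatic carbon. Going by the values given here, no step between two measured compounds is on hand, so the size of this change can only be expected. The step of a 77-fold higher number from compound 2 to compound 3 (1.89 log units; beyond the scatter) is expected to be a loss well beyond the scatter. Compound 3 is estimated at 2000 nM, with a range from 300 nM to 12000 nM.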

Compound 3, half-maximal inhibitory concentration: > 5000 nM
Compound 3: a limit, no number (the forecaster's own chance of this, stated with the estimate: 40%); middle value at least 2.5-fold (0.39 log units) away from the limit.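

In this assay, methoxycarbonyl in place of 2-methoxyphenyl on an aromatic carbon, para to a large group, gives an at least 190-fold higher number from compound 2 to compound 3 (2.28 log units; beyond the scatter), the first step read at this position. Compound 3 gives > 5000 nM, which is a limit and not a number, and the set now gathers there: the limit of > 5000 nM in this assay, at which 2 of the 3 values shown sit. At this position, methoxycarbonyl does not keep the activity seen with 2-methoxyphenyl.

From the compounds shown here alone, whether the aromatic ring alone or its methoxy group carries that activity stays open. Plain phenyl, a carboxylic acid or an amine at this place would narrow the question.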